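The source may report more compounds than this note shows. Statements on the series, on what has been measured and on what is new or still open speak of the compounds shown alone.

Measured so far:
compound 1, `Brc1ccc(N2C[C@H]3CNC[C@H]3C2)cn1`: 0.28 nM
compound 2, `CN1C[C@@H]2CN(c3ccc(-c4cccc(-c5ccccc5)c4)nc3)C[C@@H]2C1`: 9800 nM

In an assay on membranes from brain for displacement of a labelled ligand from Neuronal acetylcholine receptor; alpha4/beta2 (Rattus norvegicus) (a higher number here means a weaker inhibitor, a lower number a stronger inhibitor), compound 1 gives 0.28 nM and compound 2 gives 9800 nM. Compound 2 therefore stands at the higher of the two numbers, and its gap to compound 1 lies beyond the scatter, so of these two compound 2 is the weaker inhibitor. Compound 3, `CN1C[C@@H]2CN(c3ccc(-c4cccc([N+](=O)[O-])c4)nc3)C[C@@H]2C1`, has not yet been measured. It differs from compound 2 in one place: nitro in place of phenyl on an aromatic carbon. Among the compounds with values here, no measured pair shows this exact change, so its size is not known from the data at hand. Because compound 2 gives 9800 nM there is much room for the number to fall, and a moderate drop beyond the scatter is expected, a step of a 6.5-fold lower number from compound 2 to compound 3 (0.82 log units; beyond the scatter) in this assay. Compound 3 is thus estimated at 1500 nM, with a range from 200 nM to 12000 nM.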

Compound 3, inhibition constant: 2600 nM
Compound 3: middle estimate off by 1.7-fold (0.24 log units), on the low side; the range from low to high includes it.
By their numbers in this assay, from the lowest: compound 1; then compound 3; then compound 2.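

In this assay, replacing phenyl with nitro on this aromatic carbon, meta to a large group, gives a 3.8-fold lower number from compound 2 to compound 3 (0.58 log units; beyond the scatter), so the number does respond to what sits at this position. The change swaps a group of 6 heavy atoms, all carbon, with 0 hydrogen-bond acceptors for one of 3 heavy atoms with 2 hydrogen-bond acceptors, and this single step cannot show which of these differences matters. Nothing at hand explains why the number falls.

Going by these compounds, it remains open whether other groups on this carbon, such as an amine, a methoxy group or a carboxylic acid, would lower the number further or raise it. On these data alone, it is also open how a plain hydrogen at this position would compare with phenyl and nitro.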